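The compounds below may be only part of what the source reports. "The series", "measured", "known", "first", "only" and "open" are said of these compounds alone.

Of the compounds shown here, three built on one shared core have been tested in a functional assay on A549 cells (Homo sapiens) for antiproliferative activity, read by BrdU incorporation, with a stated time of 24 h; a lower number here means a stronger inhibitor, a higher number a weaker inhibitor. Compound 1 `O=C(CN1CCN(c2cc3c(cc2F)c(=O)c(C(=O)O)cn3C2CC2)CC1)Nc1ccccc1` is the plainest of them. In this assay compound 1 reaches only a limit of the measurement, > 100000 nM, so no number is known for it. Compound 2 `O=C(CN1CCN(c2cc3c(cc2F)c(=O)c(C(=O)O)cn3C2CC2)CC1)Nc1ccc(Cl)cc1` gives 14800 nM in this assay. Compound 3 `COc1ccc(NC(=O)CN2CCN(c3cc4c(cc3F)c(=O)c(C(=O)O)cn4C3CC3)CC2)cc1` gives 24800 nM in this assay, which places its number at the top of the two numbers that exist, yet the step of a 1.7-fold higher number from compound 2 to compound 3 (0.22 log units; within the scatter) is within the scatter, so compound 2 and compound 3 cannot be told apart. The steps of an at least 6.7-fold lower number from compound 1 to compound 2 (0.82 log units; beyond the scatter) and an at least 4.0-fold lower number from compound 1 to compound 3 (0.60 log units; beyond the scatter) both run beyond the scatter. Compound 4 `O=C(CN1CCN(c2cc3c(cc2F)c(=O)c(C(=O)O)cn3C2CC2)CC1)NC1CCCCC1` differs from compound 3 in one place: cyclohexyl in place of 4-methoxyphenyl on an amide-type nitrogen. Among the compounds with values here, no measured step removes the aromatic ring itself; the measured steps only add chloro or methoxy to it, or swap one for the other without a change beyond the scatter. The step to compound 4 is therefore expected to be modest and its direction uncertain, a 1.6-fold higher number from compound 3 to compound 4 (0.21 log units; within the scatter). Compound 4 is estimated at 40000 nM, within 12000 nM to 150000 nM.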

Compound 4, half-maximal inhibitory concentration: 20700 nM
The estimate for compound 4 lay 1.9-fold (0.29 log units) above the measured number; low and high end bracket the measured number.
By their numbers in this assay, from the lowest: compounds 2, 4 and 3 (each within the scatter of the next). At a limit, above all of these: compound 1.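

In this assay, a non-aromatic ring on the amide-type nitrogen cannot be told apart from either substituted aromatic ring: both steps are within the scatter (a 1.2-fold lower number from compound 3 to compound 4 (0.08 log units; within the scatter)) and (a 1.4-fold higher number from compound 2 to compound 4 (0.15 log units; within the scatter)). So at this position, among these compounds, an aromatic ring is not needed to give a measurable number, and plain cyclohexyl, with no chloro or methoxy on it, stands apart from the unsubstituted phenyl of compound 1 (an at least 4.8-fold lower number from compound 1 to compound 4 (0.68 log units; beyond the scatter)). Compound 1 sits at a limit, so that step gives only a bound on the gap: the limit of > 100000 nM in this assay, at which 1 of the 4 values shown sits.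

Going by these compounds, whether any ring is needed here stays open, since a methyl group or a longer alkyl chain on that nitrogen would test it. Also open, on these data alone, is whether a hydroxyl group on the cyclohexyl ring would change the number.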